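Extending the Side Chain of Compound 3

The compounds below may be only part of what the source reports. "The series", "measured", "known", "first", "only" and "open" are said of these compounds alone.

Of the compounds shown here, three have been measured in an ADME assay on microsomes from liver (Homo sapiens) for metabolic stability, using NADPH, with a stated time of 10 min; on this read-out higher numbers stand for a more stable compound and lower numbers for a less stable compound. Compound 1 (`NCCCCN(C[C@H]1Cc2cccnc2CN1)[C@H]1CCCc2cccnc21`) gives 96%, compound 2 (`NCCCCN(C[C@H]1Cc2nccnc2CN1)[C@H]1CCCc2cccnc21`) gives 84%, and compound 3 (`NC/C=C/CN(C[C@H]1Cc2ncccc2CN1)[C@H]1CCCc2cccnc21`) gives 85%. Compound 3 therefore lies within the scatter of compound 2, while the gap separating it from the higher value of compound 1 is beyond the scatter.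

Compound 4 (`NC(=O)NC/C=C\CN(C[C@H]1Cc2ncccc2CN1)[C@H]1CCCc2cccnc21`) keeps the core of compound 3 but gives up the 3-aminoprop-1-en-1-yl group, on a saturated chain carbon bound to an amine nitrogen, for a larger group with no ring: a group of 7 heavy atoms (4 carbon, 2 nitrogen, 1 oxygen; no ring) in place of a group of 4 heavy atoms (3 carbon, 1 nitrogen; no ring), on a saturated chain carbon bound to an amine nitrogen. Going by the values given here, no two measured compounds differ in one place only, so the data offer no direct precedent for this change. The expectation rests on compound 3 at 85%, and no step beyond the scatter is expected in this assay. The expected step is a number 2 percentage points lower from compound 3 to compound 4 (within the scatter), which stays within the scatter. For compound 4 the estimated value is 83%, with an expected range of 68% to 95%.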

Compound 4, percent of the compound remaining: 100%
Estimate against measurement, compound 4: 17 percentage points below, outside the stated range (above it).
By their numbers in this assay, from the lowest: compounds 2 and 3 (each within the scatter of the next); then compounds 1 and 4 (each within the scatter of the next).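

In this assay, going by these compounds alone, the substituent on a saturated chain carbon bound to an amine nitrogen proves open to change: the larger group in place of 3-aminoprop-1-en-1-yl gives a number 15 percentage points higher from compound 3 to compound 4 (beyond the scatter) as the only step here between compounds that differ in one place. The entering group has 7 heavy atoms against 4 and 2 hydrogen-bond donors against 1, and this larger group brought no loss on this read-out. Nothing available bears on why the number rose.

As far as these compounds go, one step cannot show which part of the entering group matters, so it remains open whether a plain amine on a longer chain or a carboxylic acid at this place would give a similar number. From the compounds shown here alone, it also remains open whether the same group would behave alike on the core of compound 1 or compound 2.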